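What a thiophen-2-yl group may do to compound 2

The source may report more compounds than this note shows. Statements on the series, on what has been measured and on what is new or still open speak of the compounds shown alone.

Compound 1 `CCC[S+]([O-])CCCCN=C=S`: 5960 nM
Compound 2 `CCCC[S+]([O-])CCCCN=C=S`: 5840 nM
Compound 3 `CC(C)[S+]([O-])CCCCN=C=S`: 8820 nM

These values come from a functional assay on MCF7 cells (Homo sapiens) for cytotoxicity, read by MTT assay, with a stated time of 72 h (on this read-out higher numbers stand for weaker inhibition and lower numbers for stronger inhibition), and belong to three compounds that differ only in the group on a sulfur. Compound 2 cannot be ranked against the other two, since the steps that reach it are a 1.0-fold lower number from compound 1 to compound 2 (0.01 log units; within the scatter) and a 1.5-fold higher number from compound 2 to compound 3 (0.18 log units; within the scatter) and so it sits level with both.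

Compound 4 `[O-][S+](CCCCN=C=S)Cc1cccs1` has not been measured. Its difference from compound 2 is thiophen-2-yl in place of propyl on a saturated chain carbon bound to a sulfur.

The closest evidence is those same two steps together with a 1.5-fold higher number from compound 1 to compound 3 (0.17 log units; within the scatter), which show that changing the chain on a sulfur has so far moved nothing beyond the scatter. None of the three measured compounds carries a ring, however, so the data cannot test this change directly and the range must stay wide. The expected step is a 1.2-fold lower number from compound 2 to compound 4 (0.07 log units; within the scatter) in this assay, which means no change beyond the scatter is expected. The estimated value for compound 4 is 5000 nM (expected range 2200 nM to 11000 nM).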

Compound 4, half-maximal inhibitory concentration: 4140 nM
Estimate against measurement, compound 4: 1.2-fold (0.08 log units) above; the range from low to high includes it.
By their numbers in this assay, from the lowest: compounds 4, 2, 1 and 3 (each within the scatter of the next, the first and the last beyond it).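

In this assay, swapping the open chain for thiophen-2-yl gives a 1.4-fold lower number from compound 2 to compound 4 (0.15 log units; within the scatter) and a 1.4-fold lower number from compound 1 to compound 4 (0.16 log units; within the scatter) as well, and both steps stay inside the normal spread of repeat measurements. Going by these compounds alone, the earlier compounds carried only open chains on the sulfur, so compound 4 is the first to show that a five-membered aromatic ring can sit on a saturated chain carbon bound to a sulfur with no loss of activity beyond that spread. Nothing measured here explains why the ring leaves the number about where it was.

Still open, on these data alone, is whether a phenyl ring, a furan ring or a much longer chain in the same place would behave alike. As far as these compounds go, it is also open whether a basic amine or a carboxylic acid on that ring would move the number beyond the scatter.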